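This account rests on a few compounds, and the source may have more. Where it says the series, first, only, none or still open, it means among the compounds named here.

Working notes on the shared core. For the measured compounds named here, compound 2 `Cc1ccc(CNC(=O)CN2C(=O)/C(=C/c3ccc(-c4ccc(Cl)cc4)o3)SC2=S)cc1` is the only member of the series with a number in a functional assay on K562 cells (Homo sapiens) for cytotoxicity, read by MTT assay, with a stated time of 72 h; a higher number here means a weaker inhibitor, a lower number a stronger inhibitor: compound 2 gives 45000 nM. Compound 1 `N#Cc1cc(NC(=O)CN2C(=O)/C(=C/c3ccc(-c4ccc(Cl)cc4)o3)SC2=S)ccc1C(F)(F)F` is known only as a limit; in this assay compound 1 gives > 250000 nM, which is a limit of the assay and not a number. Going by the values given here, the single measured step, an at least 5.5-fold lower number from compound 1 to compound 2 (0.74 log units; beyond the scatter), therefore rests at one end on (the limit of > 250000 nM in this assay, at which 1 of the 2 values shown sits), and its true size is open upward.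

Compound 3 `O=C(CN1C(=O)/C(=C/c2ccc(-c3ccc(Cl)cc3)o2)SC1=S)Nc1nnn[nH]1` differs from compound 2 by 1H-tetrazol-5-yl in place of 4-methylbenzyl on an amide-type nitrogen. Among the compounds with values here, the only measured step that bears on this change is the exchange on the same amide-type nitrogen, where a purely aromatic substituent sat at the limit and 4-methylbenzyl gave the one number. Compound 3 again places an aromatic ring on that nitrogen, so the expectation for compound 3 in this assay is a higher number, a step of a 3.3-fold higher number from compound 2 to compound 3 (0.52 log units; beyond the scatter), with a real chance that only a limit is reported. The estimate for compound 3 is 150000 nM, within 40000 nM to 250000 nM.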

Compound 3, half-maximal inhibitory concentration: 52000 nM
Compound 3: middle estimate off by 2.9-fold (0.46 log units), on the high side; the measured number falls inside the stated range.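

The exchange of 4-methylbenzyl for 1H-tetrazol-5-yl on the amide-type nitrogen gives, in this assay, a 1.2-fold higher number from compound 2 to compound 3 (0.06 log units; within the scatter), so two substituents that differ in ring type, in size and in the count of hydrogen-bond donors and acceptors cannot be told apart here. An aromatic ring on that nitrogen therefore does not by itself place a compound at the limit, and the contrast seen so far belongs to 3-cyano-4-(trifluoromethyl)phenyl in particular, not to aromatic substituents as a class. The second comparison gives an at least 4.8-fold lower number from compound 1 to compound 3 (0.68 log units; beyond the scatter), and this step is a bound whose true size is open upward, since one end of it is a limit and not a number: the limit of > 250000 nM in this assay, at which 1 of the 3 values shown sits.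

The compounds shown do not separate the phenyl ring of compound 1 from its nitrile and trifluoromethyl substituents, so a plain phenyl group on the amide-type nitrogen remains the open comparison. Also open, from the compounds shown here alone, is whether a carboxylic acid, an amine or a longer chain at this nitrogen would move the number beyond the scatter from compound 2 and compound 3.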